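A few compounds are considered here, and "the series" means these few. Any claim that something is new, unique, unknown or untested is made for them only; others in the source may bear on it.

The measured compounds:

Compound 1, `CC(C)CCCN(C(=O)[C@@H]1C[C@H]1c1ccccc1)c1ccc(-c2ccccc2)cc1`, gives in a functional assay for agonist activity at G protein-coupled receptor 88 (Homo sapiens), read by HTRF and cAMP accumulation (a lower number here means that less compound is needed, a higher number that more compound is needed for the effect), only the limit > 100 nM, which is a limit of the assay and not a number.
Compound 2, `CC(C)(C)[C@H](N)CN(C(=O)[C@@H]1C[C@H]1c1ccccc1)c1ccc(-c2ccccc2)cc1`, gives 11 nM.
Compound 3, `CC(C)CCNCCN(C(=O)[C@@H]1C[C@H]1c1ccccc1)c1ccc(-c2ccccc2)cc1`, gives 5.1 nM.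

Compound 3 therefore has the lowest number of the two real values shown; its nearest neighbour is compound 2, with a 2.2-fold lower number from compound 2 to compound 3 (0.33 log units; beyond the scatter). Compound 4, `O=C([C@@H]1C[C@H]1c1ccccc1)N(CCNCC1CCCC1)c1ccc(-c2ccccc2)cc1`, differs from compound 3 in one place: cyclopentyl in place of isobutyl on a saturated chain carbon bound to an amine nitrogen.

Among the measured compounds shown here, two measured steps bear loosely on this change. The step of an at least 19-fold lower number from compound 1 to compound 3 (1.29 log units; beyond the scatter) brought the amine nitrogen into the chain together with the isopentyl group, and the step of a 2.2-fold lower number from compound 2 to compound 3 (0.33 log units; beyond the scatter) shifted the amine along the chain. For the measured compounds named here, neither step kept the amine in place and varied only the carbon group on it, as the change to compound 4 does, so there is no direct precedent. Since the amine and the chain are retained, compound 4 is expected to show a step within the scatter, a 1.0-fold lower number from compound 3 to compound 4 (0.01 log units; within the scatter). Compound 4 is thus estimated at 5 nM, with a range of 2 nM to 15 nM.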

Compound 4, half-maximal effective concentration: 2.5 nM
Estimate against measurement, compound 4: 2.0-fold (0.30 log units) above; low and high end bracket the measured number.
By their numbers in this assay, from the lowest: compound 4; then compound 3; then compound 2. At a limit, above all of these: compound 1.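

In this assay, the carbon group on the amine nitrogen proves to count on its own: with the amine and the chain kept, cyclopentyl in place of isobutyl gives a 2.0-fold lower number from compound 3 to compound 4 (0.31 log units; beyond the scatter), the only step shown that varies this group alone. The same side chain also carries the series further from the primary amine, with a 4.4-fold lower number from compound 2 to compound 4 (0.64 log units; beyond the scatter), which leaves compound 4 with the lowest number of the series. The step of an at least 40-fold lower number from compound 1 to compound 4 (1.60 log units; beyond the scatter) rests on a limit and not on a number: the limit of > 100 nM in this assay, at which 1 of the 4 values shown sits.

The compounds shown leave open whether the ring itself or the larger carbon count carries the step at this position. A straight pentyl chain, a cyclobutyl or a cyclohexyl group in the same place would separate the two.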